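This account rests on a few compounds, and the source may have more. Where it says the series, first, only, none or still open, it means among the compounds named here.

For the measured compounds named here, in an ADME assay on Caco-2 cells (Homo sapiens) for permeability, in the apical to basolateral direction (a higher number here means that the compound crosses the layer faster, a lower number that the compound crosses the layer more slowly), compound 1 `Cn1cc(-c2ccc(C(F)(F)F)cc2)c2cc(F)c(C(=O)NS(=O)(=O)C3CC3)cc21` gives 46 nm/s, the only actual number available so far. Compound 2 `Cn1nc(-c2ccc(C(F)(F)F)cc2)c2cc(F)c(C(=O)NS(=O)(=O)C3CC3)cc21` reads < 15 nm/s, which is a limit of the assay and not a number. For compound 3 `Cn1cc(-c2ccc(C(F)(F)F)cc2)c2ccc(C(=O)NS(=O)(=O)C3CC3)cc21` the entry is "not determined" (no result reported). Compound 4 `Cn1cc(-c2ccc(C(F)(F)F)cc2)c2cc(F)c(C(=O)NS(C)(=O)=O)cc21` has not yet been measured. It keeps the core of compound 1 and carries methyl in place of cyclopropyl on a sulfonyl sulfur. Going by the values given here, no measured pair of compounds shows this change, so only a small downward step in this assay, close to the usual scatter, is expected. The estimated step is a 1.3-fold lower number from compound 1 to compound 4 (0.12 log units; within the scatter). Compound 4 is expected to give 35 nm/s, with an estimated range of 15 nm/s to 85 nm/s.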

Compound 4, apparent permeability: 20 nm/s
For compound 4 the middle estimate is 1.8-fold (0.24 log units) above the measured one, and the stated range covers the measured number.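

Compound 1 and compound 4 are the only pair shown that differ in one place, and they show that the group on the sulfonyl sulfur matters in this assay: methyl in place of cyclopropyl gives a 2.3-fold lower number from compound 1 to compound 4 (0.36 log units; beyond the scatter). This single pair gives the size of one change and offers no cause for it. Compound 4 still gives a number, whereas compound 2 gives only a limit of the assay: the limit of < 15 nm/s in this assay, at which 1 of the 4 values shown sits.

Still open, as far as these compounds go, is how a longer chain, such as propyl, or a phenyl ring on that sulfur would read in this assay. From the compounds shown here alone, an amine-bearing chain there is equally open.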